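The source may hold more compounds than are shown below. What is called first, only, known or untested is meant among the compounds shown, and "the series" means these compounds.

Compound 1 `Cc1ccc(-n2nncc2CN2C(=O)C3(C(C#N)=C(N)Oc4c3c3nc5ccccc5nc3c3ccccc43)c3ccccc32)cc1C`: in a functional assay on HepG2 cells (Homo sapiens) for antiproliferative activity, read by MTT assay, with a stated time of 48 h (on this read-out lower numbers stand for stronger inhibition and higher numbers for weaker inhibition), compound 1 gives > 50000 nM, which is a limit of the assay.
Compound 2 `N#CC1=C(N)Oc2c(c3nc4ccccc4nc3c3ccccc23)C12C(=O)N(Cc1cnnn1-c1cc(Cl)ccc1Cl)c1ccccc12`: in this assay compound 2 gives > 50000 nM, again a limit.
Compound 3 `Cc1ccccc1-n1nncc1CN1C(=O)C2(C(C#N)=C(N)Oc3c(N)cc4nc5ccccc5nc4c32)c2ccccc21`: in this assay compound 3 gives > 50000 nM, also a limit.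

On the numbers shown, compound 3 stands where the other two stand: every value is the limit of > 50000 nM in this assay, at which 3 of the 3 values shown sit, so no compound can be set apart from another. Among the measured compounds shown here, the only single-point step among the measured compounds, a step that the two limits leave unreadable from compound 1 to compound 2, is 2,5-dichlorophenyl in place of 3,4-dimethylphenyl on an aromatic nitrogen, and the two limits leave its size unreadable.

Compound 4 `COc1ccc(OC)c(-n2nncc2CN2C(=O)C3(C(C#N)=C(N)Oc4c(N)cc5nc6ccccc6nc5c43)c3ccccc32)c1` differs from compound 3 by 2,5-dimethoxyphenyl in place of 2-methylphenyl on an aromatic nitrogen. For the measured compounds named here, this change sits on the same aromatic nitrogen as the one measured step, which gave no readable size; the measured compounds therefore offer no step that bears on it in a way that can be weighed. With all three values at the limit, no step beyond the scatter is expected from a step that the limit leaves unreadable from compound 3 to compound 4. In this assay compound 4 is estimated at 70000 nM, with a range from 20000 nM to 250000 nM, and the assay is most likely to report only a limit once more.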

Compound 4, half-maximal inhibitory concentration: 45100 nM
The estimate for compound 4 lay 1.6-fold (0.19 log units) above the measured number, and the stated range covers the measured number.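

In this assay, among the compounds shown here, compound 4 gives 45100 nM, the first readable number for any group on this aromatic nitrogen. The change to 2,5-dimethoxyphenyl in place of 2-methylphenyl gives an at least 1.1-fold lower number from compound 3 to compound 4 (0.04 log units; that floor lies within the scatter), so this position can carry a group that brings the value inside the assay's range, but the step is only a floor and shows no gain beyond the scatter. Compound 4 stands alone as a number among the compounds shown: the limit of > 50000 nM in this assay, at which 3 of the 4 values shown sit.

The compounds shown leave open how large the step really is, and whether a single methoxy group would give a readable number as well. They also leave open whether an amine or a carboxylic acid on this phenyl ring, or 2,5-dimethoxyphenyl on the core of compound 1, would give a number beyond the scatter.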